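Diamine replacement on the urea series: open chain to piperazine

The source may report more compounds than this note shows. Statements on the series, on what has been measured and on what is new or still open speak of the compounds shown alone.

Growth inhibition measured in a functional assay on BaF3 cells (Mus musculus) for inhibition, read by CCK-8 assay, with a stated time of 72 h; a lower number here means a stronger inhibitor of growth, a higher number a weaker inhibitor of growth:
compound 1 `COc1ccc(CNc2cc(Oc3ccc(NC(=O)Nc4ccc(C)c(C(F)(F)F)c4)cc3)ncn2)cc1`: 1000 nM
compound 2 `Cc1ccc(NC(=O)Nc2ccc(Oc3cc(NCc4ccccc4)ncn3)cc2)cc1C(F)(F)F`: 3010 nM
compound 3 `CNCCN(C)c1cc(Oc2ccc(NC(=O)Nc3ccc(C)c(C(F)(F)F)c3)cc2)ncn1`: > 10000 nM

Compound 3 gives only a limit, and its standing is this: the limit of > 10000 nM in this assay, at which 1 of the 3 values shown sits.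

The next step leads to compound 4 `Cc1ccc(NC(=O)Nc2ccc(Oc3cc(N4CCNC[C@@H]4C)ncn3)cc2)cc1C(F)(F)F`, with 2-methylpiperazin-1-yl in place of methyl(2-(methylamino)ethyl)amino on an aromatic carbon.

For the measured compounds named here, two measured steps bear on this position, both ending at that limit. They are an at least 10-fold higher number from compound 1 to compound 3 (1.00 log units; beyond the scatter) and an at least 3.3-fold higher number from compound 2 to compound 3 (0.52 log units; beyond the scatter). The step of a 3.0-fold higher number from compound 1 to compound 2 (0.48 log units; beyond the scatter) concerns the methoxy group and bears on the change only indirectly. Going by the values given here, no measured pair compares the open chain with a ring. Like compound 3, compound 4 carries no benzylamino group, so the expectation rests on an at least 3.3-fold higher number from compound 2 to compound 3 (0.52 log units; beyond the scatter) and stays near the weak end of this assay.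

The expected change is small, towards a lower number if any is seen: an at least 1.6-fold lower number from compound 3 to compound 4 (0.22 log units; that floor lies within the scatter). Compound 4 is estimated at 6000 nM, with an expected range of 1800 nM to 20000 nM.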

Compound 4, concentration for 50% growth inhibition: 8120 nM
Compound 4: middle estimate off by 1.4-fold (0.13 log units), on the low side; measured number inside the range.
By their numbers in this assay, from the lowest: compound 1; then compound 2; then compound 4. At a limit, above all of these: compound 3.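

Compound 3 stands at a limit and not at a number: the limit of > 10000 nM in this assay, at which 1 of the 4 values shown sits.

In this assay the 2-methylpiperazin-1-yl group gives a measured number, but the step to the ring is an at least 1.2-fold lower number from compound 3 to compound 4 (0.09 log units; that floor lies within the scatter), so ring and open chain are not separated at this position. The ring stays behind both benzylamino groups, with a 2.7-fold higher number from compound 2 to compound 4 (0.43 log units; beyond the scatter) and an 8.1-fold higher number from compound 1 to compound 4 (0.91 log units; beyond the scatter), which places the substituted benzylamino group of compound 1 furthest ahead of it.

Open, on these data alone, is whether the opposite stereocentre form of 2-methylpiperazin-1-yl, or an unsubstituted piperazine, would read differently from compound 4. Also open, as far as these compounds go, is whether a morpholine, or a benzyl group carried on the free piperazine nitrogen, would come closer to compound 1 at 1000 nM.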